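A few compounds are considered here, and "the series" means these few. Any claim that something is new, unique, unknown or untested is made for them only; others in the source may bear on it.

In a functional assay on PC-3 cells (Homo sapiens) for cytotoxicity, read by MTT assay, with a stated time of 72 h (a lower number here means a stronger inhibitor, a higher number a weaker inhibitor), compound 1 `CNC(=O)c1cc(Oc2ccc(C3=NNC(c4cc(OC)c(OC)c(OC)c4)C3)cc2)ccn1` gives 28300 nM as its half-maximal inhibitory concentration, which is a high number on this scale. Compound 2 `CNC(=O)c1cc(Oc2ccc(C3=NNC(c4ccc([N+](=O)[O-])cc4)C3)cc2)ccn1` reads > 50000 nM and that is a limit of the assay, not a number. Among the compounds with values here, no measured step between two compounds is available here as a guide.

Compound 3 `CNC(=O)c1cc(Oc2ccc(C3=NNC(c4ccc(F)cc4)C3)cc2)ccn1` differs from compound 2 in one place, with fluoro in place of nitro on an aromatic carbon, para to a large group (fluoro in place of nitro on an aromatic carbon). A modest move toward lower numbers in this assay is expected, though another limit is quite possible. Within the data shown here, that expectation rests on compound 1 at 28300 nM as the only true number so far. The estimated change is an at least 1.6-fold lower number from compound 2 to compound 3 (0.22 log units; that floor lies within the scatter) and no large move is expected. For compound 3 the expected value is 30000 nM with an estimated range from 12000 nM to 50000 nM in this assay.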

Compound 3, half-maximal inhibitory concentration: 6770 nM
Compound 3: the middle estimate sits 4.4-fold (0.65 log units) above what was measured; the measured number lies below the stated range.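

In this assay, fluoro in place of nitro on an aromatic carbon gives an at least 7.3-fold lower number from compound 2 to compound 3 (0.86 log units; beyond the scatter), so what sits at this place on the ring clearly matters to the read-out. The change is small in atom count, with the three heavy atoms of nitro giving way to the single atom of fluoro, yet it turns a limit into a true number. The step can be stated only as a floor because compound 2 stands at a limit of the assay and not at a number: the limit of > 50000 nM in this assay, at which 1 of the 3 values shown sits.

The compounds shown cannot separate what fluoro brings from what the loss of nitro brings. As far as these compounds go, how a chlorine atom or an amine at the same place would compare also remains open, as does the true size of the step.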